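Chain Lengthening on a Lactone Series Against Leukemia Cells

The source may report more compounds than this note shows. Statements on the series, on what has been measured and on what is new or still open speak of the compounds shown alone.

The measured compounds and their values:
Compound 1, `CCCCOc1cccc(C[C@H]2C(=O)OC[C@@H]2Cc2ccccc2)c1`, gives 26000 nM in a functional assay on HL-60 cells (Homo sapiens) for cytotoxicity, read by WST assay, with a stated time of 48 h; a lower number here means that less compound is needed, a higher number that more compound is needed for the effect.
Compound 2, `CCCCCCCOc1cccc(C[C@H]2C(=O)OC[C@@H]2Cc2ccccc2)c1`, gives 81000 nM in this assay.
Compound 3, `CCCCOc1ccc(C[C@H]2C(=O)OC[C@@H]2Cc2ccccc2)cc1`, gives 23000 nM in this assay.

All three share a lactone core carrying a benzyl group and a second benzyl group whose ring bears an alkoxy chain. Compound 1 and compound 3 are built from the same atoms joined differently; the difference between the two cores is not broken down here. What their values show is that compound 3 and compound 1 lie within the scatter of each other in this assay.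

Going from compound 1 to compound 2 the change is propyl in place of hydrogen on a saturated chain carbon, four bonds along the chain from an oxygen on an aromatic ring. This gave a 3.1-fold higher number from compound 1 to compound 2 (0.49 log units; beyond the scatter), so the longer chain called for more compound.

Compound 4, `CCCCCCCOc1ccc(C[C@H]2C(=O)OC[C@@H]2Cc2ccccc2)cc1`, has not yet been measured. It differs from compound 3 by propyl in place of hydrogen on a saturated chain carbon, four bonds along the chain from an oxygen on an aromatic ring. Going by the values given here, this is the same change as the one from compound 1 to compound 2, made on the core of compound 3 instead.

For compound 4 the step is expected to be a 3.0-fold higher number from compound 3 to compound 4 (0.48 log units; beyond the scatter), resting on the single earlier case of this change, which gave a 3.1-fold higher number from compound 1 to compound 2 (0.49 log units; beyond the scatter). Among the compounds with values here, with only one precedent and a different core, the expectation is held loosely. Compound 4 is estimated at 70000 nM in this assay, with a likely range from 35000 nM to 140000 nM.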

Compound 4, half-maximal effective concentration: > 100000 nM
Compound 4: a limit, no number; the forecaster's own chance of this, stated with the estimate: 10%; middle value at least 1.4-fold (0.15 log units) from the limit.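

In this assay compound 4 gives > 100000 nM, which is a limit of the assay and not a number. The step on this core is an at least 4.3-fold higher number from compound 3 to compound 4 (0.63 log units; beyond the scatter), so propyl in place of hydrogen on the saturated chain calls for more compound here, as it did on the core of compound 1. The direction of the change therefore carries over from one core to the other, but the data do not show whether its size does: the same change on two cores in this assay, a 3.1-fold higher number (0.49 log units; beyond the scatter) from compound 1 to compound 2 and an at least 4.3-fold higher number (0.63 log units; beyond the scatter) from compound 3 to compound 4; the limit leaves it open whether they differ

The compounds shown also leave open how the number changes with a longer chain or with a chain of intermediate length, and a single pair on each core cannot show whether the rise is steady along the way. As far as these compounds go, it also remains open what an amine or a carboxylic acid would do in place of the propyl, since every chain here is made of carbon alone after the oxygen on the aromatic ring.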